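The source may report more compounds than this note shows. Statements on the series, on what has been measured and on what is new or still open speak of the compounds shown alone.

Measured so far in a physicochemical assay for lipophilicity, using the shake flask method; a lower number here means a more polar compound, a higher number a more lipophilic compound:
- compound 1 `C[C@H](Oc1ccc2ncc(/C=C/C(=O)O)c(C3CC3)c2c1)c1c(Cl)cccc1Cl` gives 3.7
- compound 2 `Cc1cc(O[C@@H](C)c2c(Cl)ccc(F)c2Cl)ccc1/C=C/C(=O)O` gives 3.2
- compound 3 `C[C@H](Oc1ccc2ncc(/C=C/C(=O)O)cc2c1)c1c(Cl)ccc(F)c1Cl` gives 2.5

Compound 3 at 2.5 stands lowest of the three. Compound 2 at 3.2 and compound 1 at 3.7 both lie higher, each beyond the scatter of repeat measurements.

The next compound to be measured is compound 4 `C[C@H](Oc1ccc2ncc(/C=C/C(=O)O)c(C(F)F)c2c1)c1c(Cl)ccc(F)c1Cl`, which differs from compound 3 in one place. The change is difluoromethyl in place of hydrogen on an aromatic carbon and it puts difluoromethyl in place of hydrogen on an aromatic carbon, opposite the ring nitrogen and ortho to a 2-carboxyethenyl group.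

Within the data shown here, no measured pair here differs in one place, so the size of this step cannot be read from the series and remains a judgement. The step of a number 0.60 log units higher from compound 3 to compound 4 (beyond the scatter) is expected to go upward and to lie beyond the scatter, ending within the span of the measured values. Compound 4 is expected at 3.1 with a range from 2.7 to 3.5 as the estimate.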

Compound 4, distribution coefficient: 3.1
For compound 4 middle estimate and measured number coincide at the digits printed, and the stated range covers the measured number.
By their numbers in this assay, from the lowest: compound 3; then compounds 4 and 2 (each within the scatter of the next); then compound 1.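

In this assay, among these compounds, the series now holds one step that can be read on its own: difluoromethyl in place of hydrogen on an aromatic carbon, opposite the ring nitrogen and ortho to a 2-carboxyethenyl group, gives a number 0.60 log units higher from compound 3 to compound 4 (beyond the scatter) as the only measure of a change at this position. The entering group carries no ring and no net charge, so this step concerns a neutral, non-cyclic group only. No measured property on hand accounts for the size of this step.

On these data alone, whether other groups at this position, such as an amine, a nitrile or a trifluoromethyl, would move the number in the same direction and by a similar amount remains open. One step also cannot show whether difluoromethyl in place of hydrogen would give a similar change elsewhere on the shared core.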